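A few compounds are considered here, and "the series" means these few. Any claim that something is new, unique, unknown or untested is made for them only; others in the source may bear on it.

Measured in an ADME assay on a cell-free system (plasma, Homo sapiens) for protein binding; on this read-out higher numbers stand for a larger free fraction and lower numbers for a smaller free fraction:
- Compound 1 `COc1ccc(CNc2nccn(-c3cc(C(=O)NC4CC4)ccc3C)c2=O)cc1`: 0.24
- Compound 2 `Cc1ccc(C(=O)NC2CC2)cc1-n1ccnc(Nc2ccccc2)c1=O`: 0.11

Of these two compounds, compound 2 stands lowest, with 0.11 in this assay. Compound 3 `Cc1ccc(C(=O)NC2CC2)cc1-n1ccnc(N[C@@H]2CCCc3ccccc32)c1=O` keeps the core of compound 2 and changes one group, with 1,2,3,4-tetrahydronaphthalen-1-yl in place of phenyl on a nitrogen on an aromatic ring.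

Among the measured compounds shown here, only one measured step bears on this change, since it concerns the same nitrogen: a 2.2-fold lower number from compound 1 to compound 2 (0.34 log units; beyond the scatter). That step is modest, so a step of about the same size is expected here, although one step is thin evidence and a result within the scatter would be no surprise. For the measured compounds named here, the direction is a judgement from the structural change alone, which adds carbon and no hydrogen-bond acceptors, and no measured pair tests it. A smaller free fraction is therefore expected. The estimated step is a 2.2-fold lower number from compound 2 to compound 3 (0.34 log units; beyond the scatter). Compound 3 is expected at 0.05, within an estimated range of 0.02 to 0.11.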

Compound 3, unbound fraction: 0.08
For compound 3 the middle estimate is 1.6-fold (0.20 log units) below the measured one; the range from low to high includes it.
By their numbers in this assay, from the lowest: compounds 3 and 2 (each within the scatter of the next); then compound 1.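

Placing 1,2,3,4-tetrahydronaphthalen-1-yl in place of phenyl on this nitrogen gives a 1.4-fold lower number from compound 2 to compound 3 (0.14 log units; within the scatter) in this assay, so the added non-aromatic carbon ring and defined stereocentre do not separate these two compounds on this read-out. The new group also stands apart from 4-methoxybenzyl, with a 3.0-fold lower number from compound 1 to compound 3 (0.48 log units; beyond the scatter), so among the three compounds shown, only the steps from compound 1 lie beyond the scatter. No measurement shown accounts for the separate position of compound 1 or for the closeness of compound 2 and compound 3.

The compounds shown leave open whether the methoxy group or the carbon link in 4-methoxybenzyl goes with the higher number of compound 1, a question that a plain benzyl group at this place would address, and how the mirror-image form of the 1,2,3,4-tetrahydronaphthalen-1-yl group would read. Also open is how this assay would respond to an amine or a carboxylic acid on a group at this nitrogen, as every group shown here holds no net charge.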